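A few compounds are considered here, and "the series" means these few. Any claim that something is new, unique, unknown or untested is made for them only; others in the source may bear on it.

Working notes on the amide side chain of the series. For the measured compounds named here, in an ADME assay on Vero cells (Chlorocebus sabaeus) for cytotoxicity, read by neutral red uptake, with a stated time of 3 days (a lower number here means that less compound is tolerated, a higher number that more compound is tolerated), compound 1 `CC(C)n1ncc2c(C(=O)NC3CCN(C)C3)cc(C3CC3)nc21` gives 33800 nM while compound 2 `CC(CN)NC(=O)c1cc(C2CC2)nc2c1cnn2C(C)C` gives 164000 nM and so holds the higher of the two numbers so far. Going by the values given here, the one measured step, a 4.9-fold higher number from compound 1 to compound 2 (0.69 log units; beyond the scatter) in this assay, put 1-(aminomethyl)ethyl in place of 1-methylpyrrolidin-3-yl on an amide-type nitrogen.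

Compound 3 `CNCCCNC(=O)c1cc(C2CC2)nc2c1cnn2C(C)C` changes the same place, with 3-(methylamino)propyl in place of 1-(aminomethyl)ethyl on an amide-type nitrogen. The count reads 3-(methylamino)propyl in place of 1-(aminomethyl)ethyl on an amide-type nitrogen and the shared core stays as it is. Neither group has a ring and neither carries a net charge.

Among the compounds with values here, the step from compound 1 is the only guide, and it is a weak one, since it removed a different group. Within the data shown here, no measured pair yet exchanges one open chain for another. The step expected in this assay is a 1.5-fold lower number from compound 2 to compound 3 (0.17 log units; within the scatter) and so none beyond the scatter, with a slight lean towards a lower number. For compound 3 the estimated value is 110000 nM with an expected range from 45000 nM to 250000 nM as the working window.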

Compound 3, half-maximal cytotoxic concentration: 281000 nM
The estimate for compound 3 lay 2.6-fold (0.41 log units) below the measured number; the measured number lies above the stated range.
By their numbers in this assay, from the lowest: compound 1; then compounds 2 and 3 (each within the scatter of the next).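

In this assay the exchange of one open chain for another, 3-(methylamino)propyl in place of 1-(aminomethyl)ethyl on an amide-type nitrogen, gives a 1.7-fold higher number from compound 2 to compound 3 (0.23 log units; within the scatter) and so does not separate the two chains, although they differ in the heavy atoms counted and in the form of the amine. Set against the ring-bearing group, the same chain gives an 8.3-fold higher number from compound 1 to compound 3 (0.92 log units; beyond the scatter) and this places both open-chain compounds, compound 2 and compound 3, apart from compound 1, with neither of the three going against that grouping at this position. No measured information bears on what lies behind these numbers.

For the compounds shown here, with only one ring-bearing group in hand, it remains open whether a piperidine or an azetidine on the same amide nitrogen would stay with compound 1 or join the open chains. Going by these compounds, it is equally open whether a longer chain, a chain ending in a dimethylamine, or one ending in a hydroxyl or a carboxylic acid in place of the amine would stay with compound 2 and compound 3.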